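Removing One Methyl Group From a Chalcone Core

The compounds below may be only part of what the source reports. "The series", "measured", "known", "first", "only" and "open" are said of these compounds alone.

Compound 1 `COc1cc(OC)c(C(=O)/C=C/c2ccccc2SC)c(OC)c1` and compound 2 `COc1cccc(/C=C/C(=O)c2c(OC)cc(OC)cc2OC)c1` are built on closely related cores; the one place where they differ is 3-methoxyphenyl in place of 2-(methylsulfanyl)phenyl on a double-bonded chain carbon bound to a double-bonded chain carbon. In a functional assay on HCT-116 cells (Homo sapiens), read by fluorescence and BrdU incorporation, with a stated time of 48 h, tested at 10 uM (a higher number here means a weaker effect of the compound at the concentration tested, a lower number a stronger effect), compound 1 gives 25%, and compound 2 gives 20%, so the step is a number 5 percentage points lower from compound 1 to compound 2 (within the scatter). Compound 3 `COc1cc(O)c(C(=O)/C=C/c2ccccc2SC)c(OC)c1` is compound 1 after a single change, (hydrogen in place of methyl on an oxygen on an aromatic ring). In this assay compound 3 gives 52%, which makes the step of a number 27 percentage points higher from compound 1 to compound 3 (beyond the scatter). Compound 4 `COc1cccc(/C=C/C(=O)c2c(O)cc(OC)cc2OC)c1` has not yet been measured. It carries the corresponding change on the core of compound 2: hydrogen in place of methyl on an oxygen on an aromatic ring. The surroundings of the changed oxygen are described in the same words for both pairs, so this is the same change seen a second time. Going by the values given here, for compound 4 the expected step is a number 27 percentage points higher from compound 2 to compound 4 (beyond the scatter), which rests on the single earlier step of a number 27 percentage points higher from compound 1 to compound 3 (beyond the scatter), with the caution that one observation is a thin basis. Compound 4 is therefore estimated to give 47% in this assay, most likely between 30% and 65%.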

Compound 4, a percentage reported as activity, at one concentration (the size of the read-out at that concentration, not a potency): 30%
Compound 4: middle estimate off by 17 percentage points, on the high side; low and high end bracket the measured number.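

In this assay the swap of methoxy to hydroxy on the core of compound 2 gives a number 10 percentage points higher from compound 2 to compound 4 (within the scatter) and so cannot be told apart from repeat scatter. The same swap therefore does not carry over at the same size from one core to the other: the same change on two cores in this assay, a number 27 percentage points higher (beyond the scatter) from compound 1 to compound 3 and a number 10 percentage points higher (within the scatter) from compound 2 to compound 4, 17 percentage points apart, beyond the scatter of two such steps. This shows that the size of the step seen on the core of compound 1 is a poor guide to its size on the core of compound 2, but two pairs cannot show what sets the gap, or how the swap would behave on any third core.

The two cores differ only by 3-methoxyphenyl in place of 2-(methylsulfanyl)phenyl, and the compounds shown leave open which feature of those groups matters. They also leave open what an ethyl group or a longer chain on that oxygen would do, or an amine in place of the hydroxy group.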